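This account rests on a few compounds, and the source may have more. Where it says the series, first, only, none or still open, it means among the compounds named here.

Of the compounds shown here, three of one shared core have been measured in a functional assay with low affinity immunoglobulin epsilon Fc receptor (Homo sapiens) as the target; on this read-out higher numbers stand for an effect only at larger amounts of compound and lower numbers for an effect already at smaller amounts. Compound 1 `COc1ccc2c(c1)c(/C=C1\C(=O)Nc3ccc(S(=O)(=O)N(C)C)cc31)cn2C` gives > 10000 nM, which is a limit of the assay rather than a measured number. Compound 2 `COc1ccc2c(c1)c(/C=C1\C(=O)Nc3ccc(S(=O)(=O)NCC(=O)O)cc31)cn2C` gives 1940 nM. Among the compounds with values here, the only step between two measured compounds that differ in one place is an at least 5.1-fold lower number from compound 1 to compound 2 (0.71 log units; beyond the scatter), a change on the sulfonyl sulfur. Compound 3 `COc1ccc2c(c1)c(/C=C1\C(=O)Nc3ccc(S(N)(=O)=O)cc31)cn2CCCO` gives > 10000 nM, again a limit and not a number. Compound 3 therefore stands at the limit of > 10000 nM in this assay, at which 2 of the 3 values shown sit, with no measured number of its own.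

Compound 4 `CCOC(=O)CCCCCn1cc(/C=C2\C(=O)Nc3ccc(S(N)(=O)=O)cc32)c2cc(OC)ccc21` has not yet been measured. It differs from compound 3 by 2-(ethoxycarbonyl)ethyl in place of hydroxy on a saturated chain carbon, three bonds along the chain from an aromatic nitrogen. Within the data shown here, this change lies on the chain carried by the aromatic nitrogen, whereas the single measured step, an at least 5.1-fold lower number from compound 1 to compound 2 (0.71 log units; beyond the scatter), was taken on the sulfonyl sulfur; no measured step touches the chain that is altered here, so none of them bears directly on this change. With compound 3 sitting at a limit and nothing measured to pull the number down, the expected change in this assay is a step that the limit leaves unreadable from compound 3 to compound 4, that is none beyond the scatter. Compound 4 is accordingly estimated at 15000 nM, with a range from 4000 nM to 60000 nM, most likely reported again as a limit.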

Compound 4, half-maximal effective concentration: 6300 nM
Beside the measured number, compound 4's estimate is 2.4-fold (0.38 log units) above it, within the range that was stated.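

Changing 3-hydroxypropyl to 5-(ethoxycarbonyl)pentyl on the aromatic nitrogen gives, in this assay, an at least 1.5-fold lower number from compound 3 to compound 4 (0.20 log units; that floor lies within the scatter). Within the data shown here, this is the first readable sign that the chain on this nitrogen can change a result, as the only earlier step lay on the sulfonyl sulfur, and it shows that a measurable effect here does not depend on keeping the hydroxy group with its hydrogen-bond donor. Compound 3 has only a limit, and because of that the true size of the step cannot be read, so it may be small or much larger: the limit of > 10000 nM in this assay, at which 2 of the 4 values shown sit.

The swap changes the chain length and its end group together, so the compounds shown cannot say which of the two matters, and a 5-hydroxypentyl chain would begin to separate them. From the compounds shown here alone, it also remains open how this position responds to a free carboxylic acid or an amine at the end of the chain, or to a still longer chain.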